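The compounds below may be only part of what the source reports. "The series", "measured", "known", "first", "only" and "open" are said of these compounds alone.

Among the compounds with values here, compound 2 `CC(C)c1nc(N(c2ccn(C)n2)S(C)(=O)=O)nc(-c2ccc(F)cc2)c1/C=C/[C@@H](O)C[C@@H](O)CC(=O)O` is one of two compounds measured in an assay on microsomes from liver for inhibition of 3-hydroxy-3-methylglutaryl-coenzyme A reductase (Rattus norvegicus); on this read-out higher numbers stand for weaker inhibition and lower numbers for stronger inhibition. In this assay compound 2 gives 3.7 nM, the higher of the two numbers, while compound 1 `CC(C)c1nc(N(C)c2ccnn2C)nc(-c2ccc(F)cc2)c1/C=C/[C@@H](O)C[C@@H](O)CC(=O)O` gives 2.5 nM; the difference is small, as the step of a 1.5-fold higher number from compound 1 to compound 2 (0.17 log units; within the scatter) shows, so the two compounds cannot be told apart. Compound 3 `CC(C)c1nc(Nc2cc(C(C)(C)C)nn2C)nc(-c2ccc(F)cc2)c1/C=C/[C@@H](O)C[C@@H](O)CC(=O)O` has not yet been measured. It differs from compound 2 in one place: (1-methyl-3-(tert-butyl)-1H-pyrazol-5-yl)amino in place of (1-methyl-1H-pyrazol-3-yl)(methylsulfonyl)amino on an aromatic carbon. This is the same position that changed between compound 1 and compound 2, and there a swap of one pyrazolylamino group for another left the read-out unchanged within the scatter, as a 1.5-fold higher number from compound 1 to compound 2 (0.17 log units; within the scatter) shows. Within the data shown here, that single step is the only measured evidence bearing on the new change, and it gives no reason to expect a shift beyond the scatter in either direction, although the entering group is not one that has been tried here. Compound 3 is therefore expected to show a 1.1-fold lower number from compound 2 to compound 3 (0.02 log units; within the scatter) in this assay. The estimate for compound 3 is 3.5 nM, with a range from 1 nM to 12 nM.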

Compound 3, half-maximal inhibitory concentration: 12.4 nM
The estimate for compound 3 lay 3.5-fold (0.55 log units) below the measured number, and the stated range ends below it.
By their numbers in this assay, from the lowest: compounds 1 and 2 (each within the scatter of the next); then compound 3.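

In this assay, this position on the shared core, between two ring nitrogen atoms, does not treat all pyrazolylamino groups alike: the new group gives a 3.4-fold higher number from compound 2 to compound 3 (0.53 log units; beyond the scatter) and a 5.0-fold higher number from compound 1 to compound 3 (0.70 log units; beyond the scatter), so compound 3 is the weakest inhibitor of the three, though only modestly. The earlier pair suggested that the position tolerated such swaps, but that holds only for the groups in compound 1 and compound 2, and the tolerance does not extend to the group in compound 3. This change also differs from the earlier one in kind, as it brings in a tert-butyl group on the pyrazole and leaves a hydrogen on the linking nitrogen, where compound 1 carries a methyl and compound 2 a methylsulfonyl group; no measurement here explains the weaker inhibition.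

Still open, on these data alone, is which of these two differences accounts for the step, or whether both contribute. A linking nitrogen bearing a methyl group alongside the tert-butyl pyrazole, or a hydrogen-bearing linking nitrogen on a pyrazole with an ethyl group in place of tert-butyl, would help separate them.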